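The source may report more compounds than this note shows. Statements on the series, on what has been measured and on what is new or still open speak of the compounds shown alone.

Measured so far:
compound 1, `C=CCO/N=C/c1c(N)ncnc1Oc1ccc(NC(=O)C2(C(=O)Nc3ccc(F)cc3)CC2)cc1F` — 3.65
compound 2, `CCOC(=O)CO/N=C/c1c(N)ncnc1Oc1ccc(NC(=O)C2(C(=O)Nc3ccc(F)cc3)CC2)cc1F` — 3.15
compound 3, `N/N=C/c1c(N)ncnc1Oc1ccc(NC(=O)C2(C(=O)Nc3ccc(F)cc3)CC2)cc1F` — 2.25

In a physicochemical assay for lipophilicity, using the shake flask method (a lower number here means a more polar compound, a higher number a more lipophilic compound), compound 1 gives the highest of the three numbers. The nearest of them is compound 2, reached by a number 0.50 log units lower from compound 1 to compound 2 (beyond the scatter), and the furthest is compound 3, reached by a number 1.40 log units lower from compound 1 to compound 3 (beyond the scatter); between these two lies a number 0.90 log units lower from compound 2 to compound 3 (beyond the scatter). All three measured steps alter the group on the double-bonded nitrogen of the shared core, so the site is clearly responsive in this assay.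

Compound 4, `Nc1ncnc(Oc2ccc(NC(=O)C3(C(=O)Nc4ccc(F)cc4)CC3)cc2F)c1/C=N/OC1CCCCC1`, has not yet been measured. It differs from compound 1 in one place: cyclohexyl in place of allyl on an oxygen. Within the data shown here, none of the measured steps adds carbon without bringing in a heteroatom, so no step copies this change directly; the two steps from compound 1 show what happens when polar groups enter at this site, and the new change runs the other way, with three more carbons and no donor or acceptor. An upward step beyond the scatter is therefore expected, estimated at a number 1.25 log units higher from compound 1 to compound 4 (beyond the scatter). Compound 4 is expected to give about 4.9, within a range from 4.3 to 5.5.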

Compound 4, partition coefficient: 4.69
For compound 4 the middle estimate is 0.21 log units above the measured one; the range from low to high includes it.
By their numbers in this assay, from the lowest: compound 3; then compound 2; then compound 1; then compound 4.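

In this assay the group on the oxygen proves able to drive the number upward as well as downward: the step with cyclohexyl in place of allyl is a number 1.04 log units higher from compound 1 to compound 4 (beyond the scatter), whereas both earlier steps from compound 1 went down. Compound 4 now stands at the top of the series, and its steps to the other two compounds are also beyond the scatter, with a number 1.54 log units higher from compound 2 to compound 4 (beyond the scatter) on exchanging (ethoxycarbonyl)methyl for cyclohexyl and a number 2.44 log units higher from compound 3 to compound 4 (beyond the scatter) on exchanging amino for cyclohexyloxy, the widest span among the four compounds. No accompanying measurement bears on why the step from allyl to cyclohexyl has this size.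

The change from compound 1 to compound 4 adds carbon, adds a ring and removes a double bond all at once, so these compounds do not separate those three differences; an open-chain hexyl group on the same oxygen, or a saturated propyl group, would pull them apart. They also leave open how an amine or a carboxylic acid at the end of a carbon chain on this oxygen would read in this assay.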